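Ring size of the hydroxylated amine on the nitro-bearing core

This account rests on a few compounds, and the source may have more. Where it says the series, first, only, none or still open, it means among the compounds named here.

Compound 2 `COc1cc[nH]c1/C=C1\C(=O)Nc2ccc([N+](=O)[O-])c(N3CC[C@@H](O)C3)c21` sits lowest of the three numbers in a functional assay on RKO cells (Homo sapiens) for antiproliferative activity, read by MTT assay, with a stated time of 5 days; a lower number here means a stronger inhibitor, a higher number a weaker inhibitor: compound 2 gives 32 nM. Compound 1 `COc1cc[nH]c1/C=C1\C(=O)Nc2ccc([N+](=O)[O-])c(N[C@H]3CC[C@H](O)CC3)c21` gives 8040 nM, and compound 3 `COc1cc[nH]c1/C=C1\C(=O)Nc2ccc(F)cc21` gives 11900 nM. Going by the values given here, the one measured step on this core, a 250-fold lower number from compound 1 to compound 2 (2.40 log units; beyond the scatter), concerns an open amine against a cyclic one, not the size of the cyclic amine itself. Compound 4 `COc1cc[nH]c1/C=C1\C(=O)Nc2ccc([N+](=O)[O-])c(N3CCCC(O)C3)c21` carries 3-hydroxypiperidin-1-yl in place of 3-hydroxypyrrolidin-1-yl on an aromatic carbon. Among the compounds with values here, no measured pair separates a five-membered from a six-membered hydroxylated ring here, so the step is expected to stay small, leaning toward a weaker number since compound 2 already marks the floor of this set. For compound 4 the estimate is 60 nM, with a range from 15 nM to 300 nM, meaning an expected step of a 1.9-fold higher number from compound 2 to compound 4 (0.27 log units; within the scatter).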

Compound 4, half-maximal inhibitory concentration: 105 nM
Compound 4: the middle estimate sits 1.8-fold (0.24 log units) below what was measured, and the stated range covers the measured number.
By their numbers in this assay, from the lowest: compound 2; then compound 4; then compounds 1 and 3 (each within the scatter of the next).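

In this assay, ring size on this aromatic carbon matters: 3-hydroxypiperidin-1-yl in place of 3-hydroxypyrrolidin-1-yl gives a 3.3-fold higher number from compound 2 to compound 4 (0.52 log units; beyond the scatter). The advantage over (4-hydroxycyclohexyl)amino is not confined to the five-membered ring, with a 77-fold lower number from compound 1 to compound 4 (1.88 log units; beyond the scatter). No evidence on hand accounts for either step.

The 3-hydroxypyrrolidin-1-yl group has a defined stereocentre and the 3-hydroxypiperidin-1-yl group has none, so ring size and stereochemistry remain unseparated in this step. On these data alone, how a plain piperidin-1-yl ring without the hydroxyl would compare also remains open.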